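A few compounds are considered here, and "the series" means these few. Any claim that something is new, unique, unknown or untested is made for them only; others in the source may bear on it.

Measured compounds in an assay on isolated protein for binding affinity to Leucine-rich repeat serine/threonine-protein kinase 2 variant G2019S (Homo sapiens), read by TR-FRET and LanthaScreen, with a stated time of 2 h; a higher number here means a weaker inhibitor, a lower number a stronger inhibitor:
Compound 1 `C[C@@H]1CCCN1c1c(C#N)c2c(N)ncnc2n1C` gives 0.7 nM.
Compound 2 `Cn1c(-c2ccccc2)c(C#N)c2c(N)ncnc21` gives 33 nM.
Compound 3 `C[C@@H]1CCCN1c1c(C#N)c2c(N)nc(N)nc2n1C` gives 13 nM.

Compound 1 has the lowest number of the three. From it, the step to compound 3 is a 19-fold higher number from compound 1 to compound 3 (1.27 log units; beyond the scatter), and the step to compound 2 is a 47-fold higher number from compound 1 to compound 2 (1.67 log units; beyond the scatter), so both changes made on the shared core of compound 1 moved the number far upward.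

Compound 4 `C[C@@H]1CCCN1c1[nH]c2ncnc(N)c2c1C#N` has not yet been measured. It differs from compound 1 by hydrogen in place of methyl on an aromatic nitrogen. Neither measured step touches that kind of position: the step from compound 1 to compound 2 and the step from compound 1 to compound 3 each alter a group on an aromatic carbon, and both were large rises. Within the data shown here, no step in the set changes anything on the aromatic nitrogen, so nothing measured here speaks directly to this change. Among the measured compounds shown here, the only guidance is that compound 1 sits lowest and each change made to it so far has raised the number. On that basis a modest rise is expected, a 4.3-fold higher number from compound 1 to compound 4 (0.63 log units; beyond the scatter). The estimate for compound 4 in this assay is therefore 3 nM, expected to fall between 0.8 nM and 12 nM.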

Compound 4, inhibition constant: 14 nM
Estimate against measurement, compound 4: 4.7-fold (0.67 log units) below; measured number above the stated range.
By their numbers in this assay, from the lowest: compound 1; then compounds 3 and 4 (each within the scatter of the next); then compound 2.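

In this assay, among these compounds, this is the first change at the aromatic nitrogen of the shared core, and it shows that this position matters: replacing methyl with hydrogen gives a 20-fold higher number from compound 1 to compound 4 (1.30 log units; beyond the scatter). The earlier steps had shown large rises only for changes on aromatic carbons, whereas here the loss of a single heavy atom on an aromatic nitrogen is enough for a large step, so the methyl of compound 1 cannot be treated as a dispensable group in this assay. Nothing measured here accounts for this rise.

The compounds shown leave open whether an ethyl group, a cyclopropyl group or a longer chain on that aromatic nitrogen would keep the number close to that of compound 1 at 0.7 nM or move it further up, as only methyl and hydrogen are compared at this place. As far as these compounds go, it also remains open whether removing the methyl would have a similar effect with phenyl in place of 2-methylpyrrolidin-1-yl, or with the added amino group of compound 3.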